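A Four-Membered Ring in Place of a Branched Chain

The source may hold more compounds than are shown below. What is called first, only, known or untested is meant among the compounds shown, and "the series" means these compounds.

Measured so far in a physicochemical assay for lipophilicity; a lower number here means a more polar compound, a higher number a more lipophilic compound:
compound 1 `CCCCN(C1=NCCN1)c1c(Br)cccc1Br`: -2.5
compound 2 `CCCCCN(C1=NCCN1)c1c(Br)cccc1Br`: 0.32
compound 3 `CC(C)CN(C1=NCCN1)c1c(Br)cccc1Br`: -0.64

Compound 3 stands second highest of the three numbers; the nearest number belongs to compound 2 and the furthest to compound 1. The steps read a number 0.96 log units lower from compound 2 to compound 3 (beyond the scatter) and a number 1.86 log units higher from compound 1 to compound 3 (beyond the scatter). Compound 4 `Brc1cccc(Br)c1N(CC1CCC1)C1=NCCN1` differs from compound 3 in one place: cyclobutyl in place of isopropyl on a saturated chain carbon bound to a nitrogen on an aromatic ring. Going by the values given here, two measured steps bear on this change. The step of a number 2.82 log units higher from compound 1 to compound 2 (beyond the scatter), methyl in place of hydrogen, went upward and large; the step of a number 0.96 log units lower from compound 2 to compound 3 (beyond the scatter), isopropyl in place of butyl, went downward and modest. A step upward beyond the scatter is therefore expected, estimated as a number 0.94 log units higher from compound 3 to compound 4 (beyond the scatter). Compound 4 is accordingly estimated at 0.3, within a range from -0.6 to 1.2.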

Compound 4, distribution coefficient: -0.06
The estimate for compound 4 lay 0.36 log units above the measured number; the measured number falls inside the stated range.
By their numbers in this assay, from the lowest: compound 1; then compound 3; then compound 4; then compound 2.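

In this assay the ring counts for something at this position: on a saturated chain carbon bound to a nitrogen on an aromatic ring, cyclobutyl in place of isopropyl gives a higher number (a number 0.58 log units higher from compound 3 to compound 4 (beyond the scatter)). Cyclobutyl still falls short of the butyl of compound 2 (a number 0.38 log units lower from compound 2 to compound 4 (beyond the scatter)) and stands far above the propyl of compound 1 (a number 2.44 log units higher from compound 1 to compound 4 (beyond the scatter)), so compound 4 lies inside the span of the earlier compounds. Nothing measured here accounts for these differences. Going by these compounds, whether cyclopropyl or cyclopentyl at this place would fall inside that span remains open.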